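The compounds below may be only part of what the source reports. "The series", "measured", "known", "first", "only" and "open" are said of these compounds alone.

Of the compounds shown here, three that share one core have been measured in an assay on CHO cells, read by calcium flux; on this read-out lower numbers stand for stronger inhibition and higher numbers for weaker inhibition. Compound 1 `CC(C)c1ccc(NC(=O)c2csc(Cc3c(Cl)cccc3Cl)n2)cc1` gives 520 nM, compound 2 `O=C(Nc1ccc(Br)cc1)c1csc(Cc2c(Cl)cccc2Cl)n1` gives 460 nM, and compound 3 `O=C(Nc1ccc(C(F)(F)C(F)(F)F)cc1)c1csc(Cc2c(Cl)cccc2Cl)n1` gives 350 nM. Compound 2 thus stands second highest of the three numbers, with compound 1 nearest and compound 3 furthest, though both of those gaps lie within the scatter. Compound 4 `O=C(Nc1cccc(Br)c1)c1csc(Cc2c(Cl)cccc2Cl)n1` is the next compound to be measured in this assay. Its change from compound 2 is 3-bromophenyl in place of 4-bromophenyl on an amide-type nitrogen: the same atoms, joined differently, so that the bromine is carried on the ring in a new arrangement. Among the compounds with values here, none of the measured steps moves a group around a ring; all three swap one group for another at the same place on the ring attached to the amide-type nitrogen, and all lie within the scatter: a 1.1-fold lower number from compound 1 to compound 2 (0.05 log units; within the scatter), a 1.5-fold lower number from compound 1 to compound 3 (0.17 log units; within the scatter) and a 1.3-fold lower number from compound 2 to compound 3 (0.12 log units; within the scatter). Within the data shown here, with no step of the same kind to lean on, and with every step at this part of the molecule so far being small, the expected step of no change at the digits printed from compound 2 to compound 4 (within the scatter) is none beyond the scatter. Compound 4 is therefore estimated at 460 nM, with a range from 180 nM to 1200 nM.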

Compound 4, half-maximal inhibitory concentration: > 4000 nM
Compound 4: only a limit was reported (the forecaster's own chance of this, stated with the estimate: 5%); middle value at least 8.6-fold (0.93 log units) from the limit.
By their numbers in this assay, from the lowest: compounds 3, 2 and 1 (each within the scatter of the next). At a limit, above all of these: compound 4.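

Moving the bromine, with no atom gained or lost, gives an at least 8.6-fold higher number from compound 2 to compound 4 (0.93 log units; beyond the scatter), the first step in this series to lie beyond the scatter. Within the data shown here, the earlier steps exchanged isopropyl, bromo and 1,1,2,2,2-pentafluoroethyl at one place on the ring and all stayed within the scatter, for instance a 1.5-fold lower number from compound 1 to compound 3 (0.17 log units; within the scatter), so they showed only that these three groups could replace one another there, whereas this change shows that where a group sits on this ring can matter far more in this assay than any of those exchanges did. From the compounds shown here alone, the reading for compound 4 is a limit of the assay and not a number, so the true size of this step stays unknown: the limit of > 4000 nM in this assay, at which 1 of the 4 values shown sits.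

The compounds shown cannot tell whether this sharp rise belongs to the bromine itself or would also appear with another group in its new place, such as a methoxy group or a nitrile, and a plain phenyl ring with no group on it would be needed as a reference point. They also give no reason for the rise, and they leave open whether the same move would matter on the 1,1,2,2,2-pentafluoroethyl or isopropyl compounds.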